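The compounds below may be only part of what the source reports. "The series", "measured", "known", "first", "only" and "open" are said of these compounds alone.

Within the data shown here, in a functional assay on HL-60 cells (Homo sapiens) for inhibition, read by MTT assay, with a stated time of 72 h (a higher number here means a weaker inhibitor, a lower number a stronger inhibitor), compound 2 `Cc1nc(-c2ccccc2)c(C(=O)N2CCN(c3ccccc3C(F)(F)F)CC2)o1` gives 120 nM, the higher of the two numbers so far, and compound 1 `COc1cccc(N2CCN(C(=O)c3oc(C)nc3-c3ccccc3)CC2)c1` gives 34.8 nM. Compound 3 `Cc1nc(-c2ccccc2)c(C(=O)N2CCN(c3ccc(Cl)c(Cl)c3)CC2)o1` keeps the shared core and changes only the group on the amine nitrogen in a ring: 3,4-dichlorophenyl in place of 2-(trifluoromethyl)phenyl on an amine nitrogen in a ring. Among the measured compounds shown here, one measured step bears on this place, a 3.4-fold higher number from compound 1 to compound 2 (0.54 log units; beyond the scatter), and it is modest. With that single step as a guide, a modest shift toward a lower number is expected in this assay. The expected change is a 1.7-fold lower number from compound 2 to compound 3 (0.23 log units; within the scatter). For compound 3 the estimate is 70 nM, with an expected range from 22 nM to 220 nM.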

Compound 3, half-maximal inhibitory concentration: 124 nM
Beside the measured number, compound 3's estimate is 1.8-fold (0.25 log units) below it; low and high end bracket the measured number.
By their numbers in this assay, from the lowest: compound 1; then compounds 2 and 3 (each within the scatter of the next).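

In this assay, 3,4-dichlorophenyl in place of 2-(trifluoromethyl)phenyl on the amine nitrogen in a ring gives a 1.0-fold higher number from compound 2 to compound 3 (0.01 log units; within the scatter) and so leaves the number effectively unchanged, although the two groups differ in what they carry on the aromatic ring. The other step, a 3.6-fold higher number from compound 1 to compound 3 (0.55 log units; beyond the scatter) with 3,4-dichlorophenyl in place of 3-methoxyphenyl, is beyond the scatter, so among these three compounds only the 3-methoxyphenyl group stands apart at this position. Nothing measured here explains this result. The compounds shown leave open how an unsubstituted phenyl or a benzyl group on this nitrogen would compare.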